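The source may report more compounds than this note shows. Statements on the series, on what has been measured and on what is new or still open speak of the compounds shown alone.

Measured so far in a functional assay on MCF7 cells (Homo sapiens) for inhibition, read by MTT assay, with a stated time of 24 h; on this read-out higher numbers stand for weaker inhibition and lower numbers for stronger inhibition:
- compound 1 `FC(F)(F)c1ccc(/C=C/[C@@H]2CCCCN2)cc1`: 1.25 ug/mL
- compound 2 `O=[N+]([O-])c1ccc(/C=C/[C@@H]2CCCCN2)cc1`: 2.15 ug/mL

Compound 2 holds the higher of the two numbers in this assay, with compound 1 nearest; the step between them, a 1.7-fold higher number from compound 1 to compound 2 (0.24 log units; within the scatter), lies within the scatter. Compound 3 `CC(=O)c1ccc(/C=C/[C@@H]2CCCCN2)cc1` differs from compound 2 by acetyl in place of nitro on an aromatic carbon. For the measured compounds named here, the only step measured so far concerns the same position on the ring and stayed within the scatter, so no step beyond the scatter is expected here: from compound 2 to compound 3 the expected change is a 1.1-fold lower number from compound 2 to compound 3 (0.03 log units; within the scatter). Compound 3 is therefore estimated at 2 ug/mL, in the range 0.9 ug/mL to 4.5 ug/mL.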

Compound 3, half-maximal inhibitory concentration: 2.7 ug/mL
Compound 3: middle estimate off by 1.4-fold (0.13 log units), on the low side; measured number inside the range.
By their numbers in this assay, from the lowest: compounds 1, 2 and 3 (each within the scatter of the next, the first and the last beyond it).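

In this assay, acetyl and nitro at this position on the aromatic ring cannot be told apart (a 1.3-fold higher number from compound 2 to compound 3 (0.10 log units; within the scatter)). Acetyl in place of trifluoromethyl gives the first step beyond the scatter at this position, and it is modest (a 2.2-fold higher number from compound 1 to compound 3 (0.33 log units; beyond the scatter)). No measurement here bears on the reason for either step.

From the compounds shown here alone, whether an amine, a carboxylic acid or a longer chain at this position would give a larger step remains open. Also open, going by these compounds, is whether the gap between trifluoromethyl and acetyl persists on other variants of the shared core.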